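Fluoro on the 1,3-benzothiazol-2-yl group

A few compounds are considered here, and "the series" means these few. Any claim that something is new, unique, unknown or untested is made for them only; others in the source may bear on it.

Of the compounds shown here, two have numbers so far. Compound 1 `COc1ccc(-c2ccc(C)n2-c2ccc(-c3nc4ccccc4s3)cc2)cc1` carries a methoxy on an aromatic carbon; in a functional assay on MCF7 cells (Homo sapiens) for cytotoxicity, read by sulforhodamine B assay, with a stated time of 48 h (on this read-out lower numbers stand for stronger inhibition of growth and higher numbers for weaker inhibition of growth), compound 1 gives 2780 nM. Compound 2 `Cc1ccc(-c2ccc([N+](=O)[O-])cc2)n1-c1ccc(-c2nc3ccccc3s2)cc1` has a nitro in place of that methoxy; in this assay compound 2 gives 2540 nM. The step between them is a 1.1-fold lower number from compound 1 to compound 2 (0.04 log units; within the scatter), so the two numbers sit within the scatter of each other, and compound 2 cannot be set apart from compound 1 on these data.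

Compound 3 `Cc1ccc(-c2ccc([N+](=O)[O-])cc2)n1-c1ccc(-c2nc3ccc(F)cc3s2)cc1` is the next compound: fluoro in place of hydrogen on an aromatic carbon. For the measured compounds named here, the only measured step, from compound 1 to compound 2, concerns a substituent swap on a different ring and left the number essentially unchanged; no measured step touches the 1,3-benzothiazol-2-yl group, so there is nothing that points either way for this change. The step expected in this assay is therefore a 1.0-fold lower number from compound 2 to compound 3 (0.01 log units; within the scatter), none beyond the scatter. For compound 3 the estimate in this assay is 2500 nM, with a range from 1000 nM to 6500 nM.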

Compound 3, concentration for 50% growth inhibition: 918 nM
For compound 3 the middle estimate is 2.7-fold (0.44 log units) above the measured one; measured number below the stated range.
By their numbers in this assay, from the lowest: compound 3; then compounds 2 and 1 (each within the scatter of the next).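

The 1,3-benzothiazol-2-yl group is the first place in the series shown to shift the number in this assay: going to the 6-fluoro-1,3-benzothiazol-2-yl group gives a 2.8-fold lower number from compound 2 to compound 3 (0.44 log units; beyond the scatter), whereas nitro in place of methoxy gave only a 1.1-fold lower number from compound 1 to compound 2 (0.04 log units; within the scatter). On this pair, then, one fluoro on an aromatic carbon of the six-membered ring, meta to a fused ring and para to a fused ring, moves the number beyond the scatter, which the substituent swap on the other ring did not do, though the step is modest and rests on a single pair. Nothing measured alongside these numbers bears on the cause of this step.

Open, going by these compounds, is whether this step belongs to fluoro itself or would also appear with another group on the same carbon, such as chloro or an amine, and whether fluoro on another carbon of this ring would give a step of similar size. Also open is whether the step carries over to the methoxy partner, compound 1, as the fluoro change is shown here only with nitro on the other ring.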